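Oxazolylmethyl Ether Replacing a Basic Side Chain

A few compounds are considered here, and "the series" means these few. Any claim that something is new, unique, unknown or untested is made for them only; others in the source may bear on it.

Of the compounds shown here, two on a shared core have been measured. Going by the values given here, compound 1 `COc1c(OCCCCNCc2ccccc2)cc(O)c2c(=O)cc(-c3ccccc3)oc12` gives 4590 nM in a functional assay on A549 cells (Homo sapiens) for cytotoxicity, read by MTT assay, with a stated time of 48 h (on this read-out higher numbers stand for weaker inhibition and lower numbers for stronger inhibition), while compound 2 `CCN(CC)CCCCOc1cc(O)c2c(=O)cc(-c3ccccc3)oc2c1OC` gives 1000 nM and thus stands at the lowest of the two numbers; the only step between them, a 4.6-fold lower number from compound 1 to compound 2 (0.66 log units; beyond the scatter), is a modest one. Compound 3 `COc1c(OCc2ncc(C)o2)cc(O)c2c(=O)cc(-c3ccccc3)oc12` differs from compound 2 by 5-methyl-1,3-oxazol-2-yl in place of 3-(diethylamino)propyl on a saturated chain carbon bound to an oxygen on an aromatic ring. Among the compounds with values here, no measured step bears directly on this change: the one known step concerns diethylamino in place of benzylamino on a saturated chain carbon, four bonds along the chain from an oxygen on an aromatic ring, and leaves the whole 3-(diethylamino)propyl portion in place, whereas here that portion itself leaves and a 5-methyl-1,3-oxazol-2-yl enters. Given that, compound 3 is expected to give a somewhat higher number, estimated at 3000 nM within 800 nM to 12000 nM, which would mean a step of a 3.0-fold higher number from compound 2 to compound 3 (0.48 log units; beyond the scatter).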

Compound 3, half-maximal inhibitory concentration: > 100000 nM
Compound 3 was reported as a limit; the forecaster's own chance of this, stated with the estimate: 10%; at least 33-fold (1.52 log units) between middle value and limit.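

In this assay, 5-methyl-1,3-oxazol-2-yl in place of 3-(diethylamino)propyl on a saturated chain carbon bound to an oxygen on an aromatic ring gives an at least 100-fold higher number from compound 2 to compound 3 (2.00 log units; beyond the scatter), whereas exchanging one amine for another had given only a 4.6-fold lower number from compound 1 to compound 2 (0.66 log units; beyond the scatter). Set against the benzylamino chain, the same replacement gives an at least 21-fold higher number from compound 1 to compound 3 (1.33 log units; beyond the scatter), so both amine-bearing chains stand well clear of the oxazole and this position tolerates far less than the earlier step suggested. The entry for compound 3 is a limit and not a number: the limit of > 100000 nM in this assay, at which 1 of the 3 values shown sits.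

The compounds shown leave open whether the amine, the chain length or the oxazole ring itself accounts for this step, as all three change together. A four-carbon chain ending in a morpholine or a hydroxyl group would begin to separate them.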